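The source may hold more compounds than are shown below. What is called first, only, known or untested is meant among the compounds shown, and "the series" means these compounds.

Measured so far in a functional assay on MKN-45 cells (Homo sapiens) for cytotoxicity, read by MTT assay, with a stated time of 72 h; a lower number here means a stronger inhibitor, a higher number a weaker inhibitor:
compound 1, `CN(C)CCNc1nc(-c2ccc(NC(=O)Nc3ccc(F)cc3)cc2)nc2ccsc12`: 330 nM
compound 2, `CN(C)CCNc1nc(-c2ccc(NC(=O)Nc3ccc(Cl)cc3)cc2)nc2ccsc12`: 250 nM

Compound 2 gives the lower of the two numbers, but its gap to compound 1 is within the scatter, so the two cannot be ordered against each other. Going by the values given here, the only measured step, a 1.3-fold lower number from compound 1 to compound 2 (0.12 log units; within the scatter), is chloro in place of fluoro on an aromatic carbon and does not separate the two compounds.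

Compound 3, `CCN(CC)CCNc1nc(-c2ccc(NC(=O)Nc3ccc(Cl)cc3)cc2)nc2ccsc12`, differs from compound 2 by diethylamino in place of dimethylamino on a saturated chain carbon, two bonds along the chain from a nitrogen on an aromatic ring. Among the compounds with values here, no measured step touches this part of the molecule: the one step known, a 1.3-fold lower number from compound 1 to compound 2 (0.12 log units; within the scatter), concerns the substituent on an aromatic carbon and says nothing about exchanging the dimethylamino. Within the data shown here, with no precedent, the working expectation for compound 3 is a step of about no change at the digits printed from compound 2 to compound 3 (within the scatter), that is, none beyond the scatter. Going by these compounds, compound 3 is therefore estimated at 250 nM in this assay, with a range of 90 nM to 700 nM that is kept wide as the change is untested here.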

Compound 3, half-maximal inhibitory concentration: 370 nM
Beside the measured number, compound 3's estimate is 1.5-fold (0.17 log units) below it; the range from low to high includes it.
By their numbers in this assay, from the lowest: compounds 2, 1 and 3 (each within the scatter of the next).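

In this assay, going by these compounds alone, the first reading at this end of the molecule is a 1.5-fold higher number from compound 2 to compound 3 (0.17 log units; within the scatter), a step that does not separate the two compounds. The amine end therefore joins the aromatic carbon as a second changed place with no step beyond the scatter, even though the group goes from 3 heavy atoms in dimethylamino to 5 in diethylamino, with the hydrogen-bond donor and acceptor counts unchanged. No available measurement bears on the reason for this result.

Going by these compounds, whether a ring amine such as morpholine or piperidine in place of diethylamino, or a longer chain than 2-(diethylamino)ethyl, would move the number beyond the scatter remains open. Also open, on these data alone, is whether the same exchange reads alike with fluoro rather than chloro on the aromatic carbon, since the dimethylamino to diethylamino change is read here only with chloro.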